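Thiazole acetic acids at the prostaglandin D2 receptor 2

This account rests on a few compounds, and the source may have more. Where it says the series, first, only, none or still open, it means among the compounds named here.

Measured so far:
compound 1 `O=C(O)Cc1sc(Cc2ccccc2-c2ccccc2)nc1-c1ccc(Cl)cc1` gives 50%
compound 2 `NS(=O)(=O)c1ccc(-c2nc(C(c3ccc(F)cc3)c3ccc(F)cc3)sc2CC(=O)O)cc1` gives 80%
compound 3 `O=C(O)Cc1sc(NC(=O)c2ccccc2)nc1-c1ccc(Cl)cc1` gives 50%

All three values come from an in vitro functional assay on HEK285-7 cells for antagonist activity at prostaglandin D2 receptor 2 (Homo sapiens), read by BRET and beta-arrestin recruitment; on this read-out higher numbers stand for larger maximal responses and lower numbers for smaller maximal responses. Compound 2 stands highest of the three numbers; compound 1 lies lower and compound 3 also lies lower, both gaps beyond the usual scatter. Compounds 1 and 3 give numbers within the scatter of each other, so no order is drawn between them.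

Compound 4 `O=C(O)Cc1sc(C(c2ccc(F)cc2)c2ccc(F)cc2)nc1-c1ccnc(O)c1` is not yet measured. It differs from compound 2 in one place: 2-hydroxypyridin-4-yl in place of 4-sulfamoylphenyl on an aromatic carbon

Going by the values given here, no step between measured compounds is available that shows the effect of this kind of exchange, so expectations rest on compound 2 alone. Because compound 2 gives 80% and the other two compounds sit well below it, a step of modest size downward is expected here, possibly only at the edge of the scatter, as a number 15 percentage points lower from compound 2 to compound 4 (beyond the scatter). For compound 4 the estimate in this assay is 65%, with a range from 45% to 85%.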

Compound 4, largest response reached (reported as efficacy), in percent of the reference or control that the assay uses: 60%
The estimate for compound 4 lay 5 percentage points above the measured number; the measured number falls inside the stated range.
By their numbers in this assay, from the lowest: compounds 1, 3 and 4 (each within the scatter of the next); then compound 2.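

At the aromatic carbon next to the ring nitrogen and next to the ring atom that bears a carboxymethyl group, this assay now gives a first one-place reading: a number 20 percentage points lower from compound 2 to compound 4 (beyond the scatter) follows when 2-hydroxypyridin-4-yl replaces 4-sulfamoylphenyl. The maximal response therefore depends on the group at this position while the rest of compound 2 stays fixed, even though both groups carry the same counts of hydrogen-bond donors and acceptors. Nothing available explains this step.

The compounds shown leave open whether the step follows from the loss of the sulfamoyl group or from the entry of the hydroxypyridine ring. Unsubstituted phenyl or 4-methanesulfonylphenyl at this position would help separate these two readings.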